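Piperazine cap exchange in a pyrrolopyrimidine antiproliferative series

The source may report more compounds than this note shows. Statements on the series, on what has been measured and on what is new or still open speak of the compounds shown alone.

Two members of the series have been measured in a functional assay on CAL-51 cells (Homo sapiens) for antiproliferative activity, read by luminescence and CellTiter-Glo, with a stated time of 3 days; a lower number here means a stronger inhibitor, a higher number a weaker inhibitor. Compound 1 `COc1cc(C(=O)N(C)C)ccc1Nc1nc(OC2COC2)c2cc[nH]c2n1` carries a dimethylamide and an oxetan-3-yloxy group and gives 1960 nM. Compound 2 `COc1cc(N2CCN(C3COC3)CC2)ccc1Nc1nc(O[C@H]2CCOC(C)(C)C2)c2cc[nH]c2n1`, with a 4-(oxetan-3-yl)piperazin-1-yl group and a larger ether substituent on the shared core, gives 84 nM. Compound 2 thus holds the lowest number of the two, and its gap to compound 1 lies well beyond the scatter of the assay. Among the measured compounds shown here, because the two differ in more than one place, the pair offers no single-change step to lean on.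

Compound 3 `COc1cc(N2CCN(C(=O)CO)CC2)ccc1Nc1nc(O[C@H]2CCOC(C)(C)C2)c2cc[nH]c2n1` is the next entry to be measured. It keeps everything in compound 2 except one group: (hydroxymethyl)carbonyl in place of oxetan-3-yl on an amine nitrogen in a ring. For the measured compounds named here, no measured step of this kind is available, so the size of the change in this assay is estimated rather than read off. A modest shift, most likely not beyond the scatter, is expected in either direction; the estimated step is a 1.3-fold higher number from compound 2 to compound 3 (0.12 log units; within the scatter). For compound 3 the expected value is 110 nM, with a range from 40 nM to 300 nM.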

Compound 3, half-maximal inhibitory concentration: 37 nM
The estimate for compound 3 lay 3.0-fold (0.47 log units) above the measured number, outside the stated range (below it).
By their numbers in this assay, from the lowest: compound 3; then compound 2; then compound 1.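

Working notes on the piperazine cap: this is the first single-change step in the series. In this assay, (hydroxymethyl)carbonyl in place of oxetan-3-yl on the amine nitrogen of the piperazine gives a 2.3-fold lower number from compound 2 to compound 3 (0.36 log units; beyond the scatter), with the larger ether substituent and the rest of the molecule held constant. The step shows that this nitrogen does not need the four-membered ring to keep the number low, since an open acyl group with the same count of heavy atoms, carrying a hydrogen-bond donor, does better than the oxetan-3-yl cap. No supporting measurement accompanies this step, so its origin stays unassigned.

The compounds shown do not separate the contribution of the carbonyl from that of the terminal hydroxyl: an acetyl group, without the hydroxyl, or a methoxyacetyl group, with the hydroxyl capped as a methyl ether, would divide the step between the two. From the compounds shown here alone, how far the position tolerates further change also remains open, for example a longer hydroxyacyl chain or a carboxylic acid on the same nitrogen, and a single step on one ether substituent cannot say whether the gain carries over to other groups on the shared core.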